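Removing the methyl from the fused core

The source may hold more compounds than are shown below. What is called first, only, known or untested is meant among the compounds shown, and "the series" means these compounds.

Going by the values given here, compound 1 `CCCCCCCC/C=C\CCCCCCC(=O)c1nc2cnccc2o1` is the one member of the series with a numerical result: in an assay on isolated protein for inhibition of Fatty-acid amide hydrolase 1 (Homo sapiens) (on this read-out higher numbers stand for weaker inhibition and lower numbers for stronger inhibition), compound 1 gives 7.2 nM. Compound 2 `CCCCCCCC/C=C\CCCCCCC(=O)c1nc2c(C)cccc2o1` carries a methyl on the fused core. In this assay compound 2 gives no number but a limit, > 100000 nM, and thus sits at the limit of > 100000 nM in this assay, at which 1 of the 2 values shown sits. Compound 3 `CCCCCCCC/C=C\CCCCCCC(=O)c1nc2ccccc2o1` has not yet been measured. It differs from compound 2 by hydrogen in place of methyl on an aromatic carbon. Among the compounds with values here, no step between measured compounds is available to size this change; what the two measured values show is a numerical result for compound 1 against a limit for compound 2. The expectation for the change is a large step towards stronger inhibition, an at least 5000-fold lower number from compound 2 to compound 3 (3.69 log units; beyond the scatter), with compound 3 estimated at 20 nM within a range of 3 nM to 200 nM. A value for compound 3 in the neighbourhood of compound 1, rather than at the limit, is what is expected.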

Compound 3, inhibition constant: 370 nM
Compound 3: middle estimate off by 19-fold (1.27 log units), on the low side, outside the stated range (above it).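

Hydrogen in place of methyl on this aromatic carbon gives an at least 270-fold lower number from compound 2 to compound 3 (2.43 log units; beyond the scatter) in this assay, so this one position separates a numerical result from a limit. That step is a bound and not a measured size, since compound 2 gives only a limit: the limit of > 100000 nM in this assay, at which 1 of the 3 values shown sits. Removing the methyl does not by itself reach the level of compound 1: replacing the six-membered aromatic ring with 1 hetero atom by the six-membered aromatic ring of carbon only gives a 51-fold higher number from compound 1 to compound 3 (1.71 log units; beyond the scatter), so the ring itself also matters in this series.

Open, from the compounds shown here alone, is whether a fluorine, a methoxy or an ethyl on this aromatic carbon would behave like hydrogen or like methyl. Also open, going by these compounds, is whether a methyl at the matching place on the core of compound 1 would give a similar step.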